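Holding the aryl group's limit in rat microsomes

This account rests on a few compounds, and the source may have more. Where it says the series, first, only, none or still open, it means among the compounds named here.

Measured in an ADME assay on microsomes from liver (Rattus norvegicus) for metabolic stability, read by LC-MS, using NADPH, at 37 degrees C; a higher number here means that the compound lasts longer, a lower number that the compound disappears faster:
- Compound 1 `Cc1ccccc1-c1nc(CN2CCC(C(=O)NCCCN3CCC(C)CC3)CC2)c(C)o1`: > 0.5 h, a limit of the assay
- Compound 2 `Cc1oc(-c2ccc(Cl)c(Cl)c2)nc1CN1CCC(C(=O)NCCCN2C[C@H](C)C[C@H](C)C2)CC1`: > 0.5 h, a limit of the assay
- Compound 3 `Cc1ccccc1-c1nc(CN2CCC(C(=O)NCCCCN3C[C@H](C)C[C@H](C)C3)CC2)c(C)o1`: 0.2 h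

Compound 2 sits at the limit of > 0.5 h in this assay, at which 2 of the 3 values shown sit. Its true half-life is therefore not known as a number.

Compound 4 `Cc1ccc(-c2nc(CN3CCC(C(=O)NCCCN4C[C@H](C)C[C@H](C)C4)CC3)c(C)o2)cc1` differs from compound 2 by one change, with 4-methylphenyl in place of 3,4-dichlorophenyl on an aromatic carbon.

Among the measured compounds shown here, the only measured step is an at least 2.5-fold lower number from compound 1 to compound 3 (0.39 log units; beyond the scatter). That step lies on a saturated chain, not at this aromatic carbon, so its size cannot be carried over. It shows only that a fall beyond the scatter can occur in this small set. For the measured compounds named here, no measured step covers the aromatic change, so no step beyond the scatter is expected in this assay, though a modest fall remains possible.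

The estimated change is an at least 1.1-fold lower number from compound 2 to compound 4 (0.04 log units; that floor lies within the scatter).

For compound 4 the expected half-life is 0.45 h.

The estimated range for compound 4 runs from 0.2 h to 0.9 h.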

Compound 4, half-life: > 0.5 h
Compound 4 was reported as a limit; the forecaster's own chance of this, stated with the estimate: 50%; middle value at least 1.1-fold (0.04 log units) from the limit.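

Compound 2 and compound 4 both stand at a limit of the assay, so no step between them can be read: the limit of > 0.5 h in this assay, at which 3 of the 4 values shown sit.

The compounds shown leave open how the half-life changes with 4-methylphenyl in place of 3,4-dichlorophenyl.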